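Phenyl to phenoxy on the shared core of compound 1

The compounds below may be only part of what the source reports. "The series", "measured", "known", "first", "only" and "open" are said of these compounds alone.

Two compounds carry a number in an in vitro functional assay on 1321-N1 cells for agonist activity at Free fatty acid receptor 1 (Homo sapiens), read by fluorescence, spectrophotometry and calcium flux; on this read-out higher numbers stand for an effect only at larger amounts of compound and lower numbers for an effect already at smaller amounts. Compound 1 `O=C(O)CCc1ccc(C#Cc2ccnc(-c3ccccc3)c2)cc1` gives 186 nM and is the lowest of the two numbers. Compound 2 `Cc1cnc(Cl)nc1C#Cc1ccc(CCC(=O)O)cc1` gives 4270 nM in this assay, a gap that lies beyond the scatter; the two differ in several places at once, so nothing further is drawn from that pair.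

Compound 3 `O=C(O)CCc1ccc(C#Cc2ccnc(Oc3ccccc3)c2)cc1` is not yet measured. It differs from compound 1 in one place: phenoxy in place of phenyl on an aromatic carbon. Phenoxy in place of phenyl on an aromatic carbon, next to the ring nitrogen and meta to a large group. The rest of the shared core, including the propanoic acid, is unchanged.

Within the data shown here, no step between measured compounds bears on this change. With the ring of the phenyl kept and only the linking oxygen added, a step of moderate size is expected, most likely toward a higher number, though a value within the scatter of compound 1 cannot be excluded. The step from compound 1 to compound 3 is thus estimated as a 1.9-fold higher number from compound 1 to compound 3 (0.27 log units; within the scatter). For compound 3 in this assay the expected value is 350 nM, with a range from 110 nM to 1300 nM.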

Compound 3, half-maximal effective concentration: 479 nM
For compound 3 the middle estimate is 1.4-fold (0.14 log units) below the measured one; the range from low to high includes it.
By their numbers in this assay, from the lowest: compound 1; then compound 3; then compound 2.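

In this assay, among these compounds, phenoxy in place of phenyl on an aromatic carbon, next to the ring nitrogen and meta to a large group, gives a 2.6-fold higher number from compound 1 to compound 3 (0.41 log units; beyond the scatter); this modest step is the first that can be read at a single place. Both groups carry the same six-membered aromatic ring of carbon only, so the step reads the added linking oxygen with that ring kept, and at this place the directly attached phenyl holds the lower number of the two while the phenoxy analogue keeps a measurable effect. Nothing at hand accounts for the direction or the size of this step.

One step at one place leaves open whether other links between this carbon and the ring would fall nearer to compound 1 or to compound 3, for example the methylene link of a benzyl group or the amine link of an anilino group. Also open, on these data alone, is whether the step would keep its size with substituents on the phenoxy ring, such as fluoro or methoxy, or with a change to the propanoic acid chain of the shared core.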